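Isopropyl for Hydrogen on an Amino Group at the Limit

The source may report more compounds than this note shows. Statements on the series, on what has been measured and on what is new or still open speak of the compounds shown alone.

Compound 2 `Nc1nc2ccccn2c1-c1ccc(O)cc1` carries an amino group on its aromatic core and has been tested in an assay on isolated protein for inhibition of ubiquitin carboxyl-terminal hydrolase 47 (Homo sapiens); on this read-out higher numbers stand for weaker inhibition and lower numbers for stronger inhibition. In this assay compound 2 gives only a limit, > 100000 nM, and no number. Compound 1 `CC(=O)Nc1nc2ccccn2c1-c1ccc(O)cc1`, which carries an acetyl group on that same nitrogen, also gives only a limit in this assay, > 100000 nM. The step that the two limits leave unreadable from compound 1 to compound 2 is unreadable because of the limit of > 100000 nM in this assay, at which 2 of the 2 values shown sit. Compound 3 `CC(C)Nc1nc2ccccn2c1-c1ccc(O)cc1` is not yet measured; it differs from compound 2 by isopropyl in place of hydrogen on a nitrogen on an aromatic ring. Among the measured compounds shown here, the single measured step bears on a different change, and its size is not known, so no step in this assay in either direction can be expected on this basis. Compound 3 is therefore expected to give about 100000 nM, with a range from 20000 nM to 300000 nM. The expected step is a number no higher from compound 2 to compound 3 (the limit leaves the size open).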

Compound 3, half-maximal inhibitory concentration: > 100000 nM
Compound 3: only a limit was reported (the forecaster's own chance of this, stated with the estimate: 80%); the middle value lies on the limit itself.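

No step among compound 1, compound 2 and compound 3 can be read in this assay, because all three give only a limit: the limit of > 100000 nM in this assay, at which 3 of the 3 values shown sit.

The compounds shown leave open how strongly each one inhibits the protein, and whether hydrogen, acetyl or isopropyl on that nitrogen makes any difference.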